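A few compounds are considered here, and "the series" means these few. Any claim that something is new, unique, unknown or untested is made for them only; others in the source may bear on it.

In an assay on isolated protein for inhibition of malate dehydrogenase, mitochondrial (Sus scrofa), with stated times of 45 min and 30 min (on this read-out higher numbers stand for weaker inhibition and lower numbers for stronger inhibition), compound 1 `C=Cc1ccc(S(=O)(=O)Nc2ccc3oc(-c4ccccc4)nc3c2)cc1` gives > 63000 nM, which is a limit of the assay rather than a number. Compound 2 `O=S(=O)(Nc1ccc2oc(-c3ccccc3)nc2c1)c1cccc(F)c1` gives > 63000 nM in this assay, again only a limit. Compound 3 `CS(=O)(=O)Nc1ccc(-c2nc3ccccc3o2)cc1` likewise gives > 63000 nM, also a limit. The step that the two limits leave unreadable from compound 1 to compound 2 therefore cannot be read, and compound 2 stands at the limit where every value shown sits (the limit of > 63000 nM in this assay, at which 3 of the 3 values shown sit). Compound 4 `O=S(=O)(Nc1ccc2oc(-c3ccccc3)nc2c1)c1cccc(Cl)c1` differs from compound 2 by chloro in place of fluoro on an aromatic carbon. For the measured compounds named here, no measured step has a readable size, so no step beyond the scatter is expected in either direction. Compound 4 is expected to give about 100000 nM, within 30000 nM to 400000 nM, and most probably to be reported only as a limit again. The expected step is a step that the limit leaves unreadable from compound 2 to compound 4, within the scatter.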

Compound 4, half-maximal inhibitory concentration: > 63000 nM
Compound 4: a limit, no number; the forecaster's own chance of this, stated with the estimate: 85%; the middle value lies beyond the limit too.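

The steps from compound 1 and from compound 2 to compound 4 cannot be read, since these compounds give no numbers, only a limit of the assay: the limit of > 63000 nM in this assay, at which 4 of the 4 values shown sit.

The compounds shown leave open whether any group on the sulfonyl sulfur changes inhibition in this assay.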